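This account rests on a few compounds, and the source may have more. Where it says the series, first, only, none or still open, it means among the compounds named here.

Compound 1 `CC[C@H]1CC[C@H](c2ccc(NC(=S)Nc3cccc(C(F)(F)F)c3)cc2)CC1` gives 10000 nM
Compound 2 `FC(F)(F)c1cccc(NC(=S)Nc2ccc(I)cc2)c1` gives 9500 nM
Compound 3 `CCCC[C@H]1CC[C@H](c2ccc(NC(=S)Nc3cccc(C(F)(F)F)c3)cc2)CC1` gives 17000 nM

All three values come from an ADME assay on Vero 76 cells (Chlorocebus sabaeus) for cytotoxicity, read by crystal violet staining, with a stated time of 96 h; on this read-out lower numbers stand for higher toxicity in this test and higher numbers for lower toxicity in this test. Compound 2 stands within the scatter of both other compounds, with a 1.1-fold lower number from compound 1 to compound 2 (0.02 log units; within the scatter) on one side and a 1.8-fold higher number from compound 2 to compound 3 (0.25 log units; within the scatter) on the other. The remaining pair, a 1.7-fold higher number from compound 1 to compound 3 (0.23 log units; within the scatter), also stays within the scatter.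

Compound 4 `CCNC(=S)Nc1cccc(C(F)(F)F)c1` has not yet been measured. Its difference from compound 2 is ethyl in place of 4-iodophenyl on an amide-type nitrogen. The measured steps bear on this only indirectly. They exchange iodo for a substituted cyclohexyl group or lengthen a chain, and none of them takes the aromatic ring away from that nitrogen, so the data do not show what its loss does. What they do show is that compound 3, at 17000 nM, gives no sign of a falling number when iodo is exchanged for 4-butylcyclohexyl. The change to compound 4 is nevertheless greater than any measured here, so a moderate rise beyond the scatter is expected, with wide uncertainty. The estimated change is a 3.7-fold higher number from compound 2 to compound 4 (0.57 log units; beyond the scatter). In this assay the estimate for compound 4 is 35000 nM, with an expected range from 10000 nM to 100000 nM.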

Compound 4, half-maximal cytotoxic concentration: > 100000 nM
Compound 4: only a limit was reported; the forecaster's own chance of this, stated with the estimate: 30%; middle value at least 2.8-fold (0.45 log units) away from the limit.
By their numbers in this assay, from the lowest: compounds 2, 1 and 3 (each within the scatter of the next). At a limit, above all of these: compound 4.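

In this assay compound 4 gives > 100000 nM, a limit of the assay and not a number. Ethyl in place of 4-iodophenyl on the amide-type nitrogen gives an at least 10-fold higher number from compound 2 to compound 4 (1.02 log units; beyond the scatter), so this position shows what none of the earlier steps could: the changes among compound 1, compound 2 and compound 3 all kept an aromatic ring on that nitrogen and stayed within the scatter, whereas this one takes the ring away and moves the read-out well beyond it, towards lower toxicity in this test. The size of that shift is only a lower bound, and the finding rests on a single compound at the top of the measurable range: the limit of > 100000 nM in this assay, at which 1 of the 4 values shown sits.

The step removes the six-membered aromatic ring and the iodine together and also shortens the group, so the compounds shown do not separate the loss of the ring from the loss of iodine or of size. From the compounds shown here alone, an unsubstituted phenyl, a cyclohexyl or a butyl chain on that amide-type nitrogen would each bear on this, and whether such groups would stay near compound 2 or move towards compound 4 remains open.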